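This account rests on a few compounds, and the source may have more. Where it says the series, first, only, none or still open, it means among the compounds named here.

In a functional assay on SK-N-AS cells (Homo sapiens) for antiproliferative activity, with a stated time of 72 h (a lower number here means a stronger inhibitor, a higher number a weaker inhibitor), compound 1 `Cc1ccc(NC(=O)CCN(Cc2ccc(C(=O)NO)cc2)C(=O)c2cc(C)cc(C)c2)cc1` gives 220 nM. Compound 2 `Cc1cc(C)cc(C(=O)N(CCC(=O)NCc2ccccc2)Cc2ccc(C(=O)NO)cc2)c1` gives 1860 nM in this assay, and compound 3 `CN(C)c1ccc(C(=O)N(CCC(=O)NCc2ccccc2)Cc2ccc(C(=O)NO)cc2)cc1` gives 1420 nM there. The step of an 8.5-fold lower number from compound 2 to compound 1 (0.93 log units; beyond the scatter) goes with the change (4-methylphenyl in place of benzyl on an amide-type nitrogen), while the step of a 1.3-fold lower number from compound 2 to compound 3 (0.12 log units; within the scatter) goes with the change 4-(dimethylamino)phenyl in place of 3,5-dimethylphenyl on a carbonyl carbon and leaves the two numbers within the scatter of each other.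

Compound 4 `Cc1ccc(NC(=O)CCN(Cc2ccc(C(=O)NO)cc2)C(=O)c2ccc(N(C)C)cc2)cc1` has not been measured in this assay. It is obtained from compound 3 by the change (4-methylphenyl in place of benzyl on an amide-type nitrogen), which is the same change already made from compound 2 to compound 1, and it occurs twice among these four compounds. The cores of compound 3 and compound 2 differ by 4-(dimethylamino)phenyl in place of 3,5-dimethylphenyl on a carbonyl carbon, and the place of the change is the same in both pairs, so the change is the same one in a different core.

Among the compounds with values here, since the only precedent for this change is the step of an 8.5-fold lower number from compound 2 to compound 1 (0.93 log units; beyond the scatter), and since the change 4-(dimethylamino)phenyl in place of 3,5-dimethylphenyl on a carbonyl carbon itself moved the number little, compound 4 is expected to sit well below compound 3 in this assay. The expected step is a 6.5-fold lower number from compound 3 to compound 4 (0.81 log units; beyond the scatter), somewhat smaller than the measured one, because an 8.5-fold lower number from compound 2 to compound 1 (0.93 log units; beyond the scatter) rests on a single pair and may not carry over in full. Compound 4 is therefore estimated at 220 nM in this assay, with a likely range from 80 nM to 600 nM.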

Compound 4, half-maximal inhibitory concentration: 400 nM
Compound 4: middle estimate off by 1.8-fold (0.26 log units), on the low side; the measured number falls inside the stated range.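

In this assay, within the data shown here, 4-methylphenyl in place of benzyl on an amide-type nitrogen again goes with a lower number on the second core, a 3.6-fold lower number from compound 3 to compound 4 (0.55 log units; beyond the scatter), so the step points the same way on both cores, and its two sizes cannot be told apart: the same change on two cores in this assay, an 8.5-fold lower number (0.93 log units; beyond the scatter) from compound 2 to compound 1 and a 3.6-fold lower number (0.55 log units; beyond the scatter) from compound 3 to compound 4, 2.4-fold (0.38 log units) apart, within the scatter of two such steps The other change, 4-(dimethylamino)phenyl in place of 3,5-dimethylphenyl on a carbonyl carbon, stays within the scatter with either group on the nitrogen, a 1.8-fold higher number from compound 1 to compound 4 (0.26 log units; within the scatter), and the two readings of this change do not differ either: the same change on two cores in this assay, a 1.3-fold lower number (0.12 log units; within the scatter) from compound 2 to compound 3 and a 1.8-fold higher number (0.26 log units; within the scatter) from compound 1 to compound 4, 2.4-fold (0.38 log units) apart, within the scatter of two such steps Together, the four compounds show that the two changes can be read side by side on these two cores, but they rest on only two pairs for each change and do not show that the step keeps a fixed size or that it carries to any other core.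

The compounds shown leave open whether a plain phenyl, a 4-chlorophenyl or a 2-phenylethyl on that nitrogen would follow 4-methylphenyl or benzyl. They also leave open whether the step would survive on the carbonyl side with a 4-methoxyphenyl or a pyridine ring, or with a longer chain leading to the amide.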